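This account rests on a few compounds, and the source may have more. Where it says the series, first, only, none or still open, it means among the compounds named here.

Compound 1 (`CCNC(=O)Nc1sc2ccccc2c1C(=O)N1CCN(C2CCN(C(=O)CC)CC2)CC1`), compound 2 (`CCNC(=O)Nc1sc2ccccc2c1C(=O)N1CCN(C2CCN(C(=O)C(C)(C)C)CC2)CC1`) and compound 3 (`CCNC(=O)Nc1sc2ccccc2c1C(=O)N1CCN(C2CCN(C(=O)OC(C)C)CC2)CC1`) share one core and differ in the group on a carbonyl carbon whose other neighbour is an amide-type nitrogen in a ring. In a functional assay on HepG2 cells (Homo sapiens) for inhibition, read by scintillation counting, with a stated time of 2 h (on this read-out lower numbers stand for stronger inhibition and higher numbers for weaker inhibition), compound 1 has the entry "not determined" (no result reported), so it offers no number for comparison. In this assay compound 2 gives 450 nM, the sole figure in the series, so its standing cannot yet be judged against any other compound. Compound 3 has not been measured. It carries isopropoxy in place of tert-butyl on a carbonyl carbon. Among the measured compounds shown here, no measured pair shows what this exchange does, so the expectation rests on the change itself and on compound 2 at 450 nM. In this assay no step beyond the scatter is expected, with any shift more likely a slight move towards stronger inhibition. The expected change is a 1.3-fold lower number from compound 2 to compound 3 (0.11 log units; within the scatter). For compound 3 the estimate is 350 nM, with an expected range of 120 nM to 1000 nM.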

Compound 3, half-maximal inhibitory concentration: 208 nM
Estimate against measurement, compound 3: 1.7-fold (0.23 log units) above, within the range that was stated.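

In this assay, among the compounds shown here, the exchange of tert-butyl for isopropoxy on a carbonyl carbon gives a 2.2-fold lower number from compound 2 to compound 3 (0.34 log units; beyond the scatter) and provides the first readable step at this position. The step is modest, but it shows that inhibition is retained and somewhat stronger when a group of the same heavy-atom count, 4, has an oxygen in place of one carbon and brings 1 hydrogen-bond acceptor to this carbonyl carbon, with compound 3 at 208 nM in this assay. No measured property or other information shown accounts for this difference, so it stands as an observation on this single pair of compounds.

For the compounds shown here, compound 1 has no number, which leaves the single step from compound 2 to compound 3 as the only reading at this position and gives no trend across the series. The compounds shown leave open whether the step would extend to a smaller methoxy group, a larger benzyloxy group or a dimethylamino group on the same carbonyl carbon, and whether any of these would give a number lower than that of compound 3.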